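This account rests on a few compounds, and the source may have more. Where it says the series, first, only, none or still open, it means among the compounds named here.

Compound 3 `Cc1ccc(Cn2cc(CSC(=S)N3CCN(C(=O)NC(C)C)CC3)nn2)cc1` sits second highest of the three numbers in a functional assay on MGC-803 cells (Homo sapiens) for cytotoxicity, read by MTT assay, with a stated time of 72 h; on this read-out higher numbers stand for weaker inhibition and lower numbers for stronger inhibition: compound 2 `Cc1ccc(Cn2cc(CSC(=S)N3CCN(C(N)=O)CC3)nn2)cc1` gives 29900 nM, compound 3 gives 16600 nM, and compound 1 `CCN(C)C(=O)N1CCN(C(=S)SCc2cn(Cc3ccc(F)cc3)nn2)CC1` gives 1550 nM. For the measured compounds named here, the only single-point step measured, a 1.8-fold lower number from compound 2 to compound 3 (0.26 log units; within the scatter), lay within the scatter. Compound 4 `CCN(C)C(=O)N1CCN(C(=S)SCc2cn(Cc3ccc(C)cc3)nn2)CC1` differs from compound 3 by ethyl(methyl)amino in place of isopropylamino on a carbonyl carbon. Going by the values given here, no measured step covers this exact swap; compound 1, which carries the same ethyl(methyl)amino group, shows a markedly lower number than compound 3 but also differs elsewhere, so its bearing is uncertain. Compound 4 is therefore expected to show a moderate drop, a 3.0-fold lower number from compound 3 to compound 4 (0.48 log units; beyond the scatter). Compound 4 is estimated at 5500 nM, within 1300 nM to 22000 nM.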

Compound 4, half-maximal inhibitory concentration: 8270 nM
The estimate for compound 4 lay 1.5-fold (0.18 log units) below the measured number, within the range that was stated.
By their numbers in this assay, from the lowest: compound 1; then compounds 4, 3 and 2 (each within the scatter of the next, the first and the last beyond it).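

In this assay, ethyl(methyl)amino in place of isopropylamino on the carbonyl carbon gives a 2.0-fold lower number from compound 3 to compound 4 (0.30 log units; within the scatter), so losing that group's one hydrogen-bond donor brings no clear change at this position. Set against the plain amino group, the same ethyl(methyl)amino gives a 3.6-fold lower number from compound 2 to compound 4 (0.56 log units; beyond the scatter) and is the first step here to clear the scatter. With ethyl(methyl)amino held fixed, methyl in place of fluoro on an aromatic carbon gives a 5.3-fold higher number from compound 1 to compound 4 (0.73 log units; beyond the scatter), which shows that the low number of compound 1 depends on the aromatic fluoro as well.

No measurement at hand explains these steps. Going by these compounds, whether a morpholine or pyrrolidine on the carbonyl carbon, or a chloro group on the aromatic carbon, would shift the number remains open.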